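The compounds below may be only part of what the source reports. "The series", "measured", "known", "first", "only" and "open" are said of these compounds alone.

Measured so far in an assay on isolated protein for inhibition of acid ceramidase (Homo sapiens), read by LC-MS, with a stated time of 1 h; a higher number here means a weaker inhibitor, a lower number a stronger inhibitor:
- compound 1 `O=C(NCCCCc1ccccc1)n1cc(-c2cccnc2)oc1=O`: 70 nM
- compound 2 `O=C(NCCCCc1ccccc1)n1cc(-c2ccncc2)oc1=O`: 18 nM

Compound 2 stands lowest of the two numbers in this assay. Going by the values given here, the only measured step, a 3.9-fold lower number from compound 1 to compound 2 (0.59 log units; beyond the scatter), separates the two compounds and shows that the ring attached to the shared core matters by a modest amount.

Compound 3 `O=C(NCCCCc1ccccc1)n1cc(-c2nccs2)oc1=O` is not yet measured. It differs from compound 2 by 1,3-thiazol-2-yl in place of pyridin-4-yl on an aromatic carbon. Among the compounds with values here, no measured step exchanges a six-membered aromatic ring for a five-membered one, so nothing speaks directly to this change. Within the data shown here, the one step that bears on it at all is a 3.9-fold lower number from compound 1 to compound 2 (0.59 log units; beyond the scatter), which concerns only the arrangement of a single ring nitrogen within an otherwise unchanged ring; it sets the scale of what a change of the attached ring has done here, a modest step. Among the measured compounds shown here, for compound 3 a step of comparable size in this assay is therefore expected, with the direction open, and since compound 2 holds the lowest number so far a somewhat higher number is the more likely outcome. The estimate for compound 3 in this assay is 40 nM, with a range of 10 nM to 160 nM. This estimate means an expected 2.2-fold higher number from compound 2 to compound 3 (0.35 log units; beyond the scatter).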

Compound 3, half-maximal inhibitory concentration: 59 nM
Estimate against measurement, compound 3: 1.5-fold (0.17 log units) below; measured number inside the range.
By their numbers in this assay, from the lowest: compound 2; then compounds 3 and 1 (each within the scatter of the next).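

At this position, next to the ring oxygen of the shared core, a five-membered aromatic ring can now be compared with a six-membered one in this assay: 1,3-thiazol-2-yl in place of pyridin-4-yl gives a 3.3-fold higher number from compound 2 to compound 3 (0.52 log units; beyond the scatter), a modest step beyond the scatter. The same exchange starting from pyridin-3-yl gives a 1.2-fold lower number from compound 1 to compound 3 (0.07 log units; within the scatter), so compound 3 and compound 1 do not separate, and ring size alone does not set the number: one six-membered ring stands apart from the 1,3-thiazol-2-yl ring and the other does not. No supporting data bear on why compound 2 stands apart from the other two.

Still open, going by these compounds, is whether the standing of pyridin-4-yl extends to a plain phenyl ring or to a pyridin-4-yl ring carrying an amine, and whether a 1,3-oxazol-2-yl ring would sit with compound 3. On these data alone, all three compounds share the same phenylbutyl chain, so how these ring steps would read with a shorter chain also remains open.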